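Methoxy for Fluoro: Expected Clearance of Compound 4

The source may hold more compounds than are shown below. What is called first, only, known or untested is meant among the compounds shown, and "the series" means these compounds.

Three compounds sharing one core have been measured in an ADME assay on microsomes from liver (Homo sapiens) for metabolic stability, tested at 2.5 uM; on this read-out higher numbers stand for fast clearance and lower numbers for slow clearance:
Compound 1 `COc1cccc(-c2c(S(=O)(=O)c3ccc(C)c(F)c3)cnc3c(F)cccc23)c1` gives 4.02 mL/min.
Compound 2 `COc1cccc(-c2c(S(=O)(=O)c3cc(F)cc(F)c3)cnc3c(F)cccc23)c1` gives 2.76 mL/min.
Compound 3 `O=S(=O)(c1cccc(F)c1)c1cnc2c(F)cccc2c1-c1cccc(F)c1` gives 1.14 mL/min.

Compound 3 stands lowest of the three, so it is cleared most slowly; compound 1 and compound 2 both lie beyond the scatter above it, while compound 1 and compound 2 are within the scatter of each other.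

Compound 4 `COc1cccc(-c2c(S(=O)(=O)c3cccc(F)c3)cnc3c(F)cccc23)c1` is yet to be measured in this assay. It differs from compound 3 in one place: methoxy in place of fluoro on an aromatic carbon.

Going by the values given here, only one single-place step has been measured, a 1.5-fold lower number from compound 1 to compound 2 (0.16 log units; within the scatter), and it concerns the ring on the sulfonyl sulfur, not the ring changed here, so no measured step bears directly on this change. What the values do show is that compound 1 and compound 2, which both carry 3-methoxyphenyl where compound 3 carries 3-fluorophenyl, give higher numbers than compound 3, though each of them also differs from compound 3 on the sulfonyl ring, so the effect of the methoxy cannot be separated cleanly.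

Compound 4 is therefore expected to move toward those two, with an estimated step of a 2.2-fold higher number from compound 3 to compound 4 (0.34 log units; beyond the scatter), giving an expected 2.5 mL/min with a range from 1.2 mL/min to 5 mL/min.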

Compound 4, intrinsic clearance in a liver preparation (reported as CLH), per the amount of preparation that the assay uses: 2.6 mL/min
Beside the measured number, compound 4's estimate is 1.0-fold (0.02 log units) below it, and the stated range covers the measured number.
By their numbers in this assay, from the lowest: compound 3; then compounds 4, 2 and 1 (each within the scatter of the next).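

In this assay, going by these compounds alone, the change from 3-fluorophenyl to 3-methoxyphenyl gives a 2.3-fold higher number from compound 3 to compound 4 (0.36 log units; beyond the scatter) with nothing else altered, the first view of this change on its own. With 3-methoxyphenyl held fixed, two changes on the ring on the sulfonyl sulfur stay within the scatter: hydrogen in place of fluoro gives a 1.1-fold lower number from compound 2 to compound 4 (0.03 log units; within the scatter) and hydrogen in place of methyl gives a 1.5-fold lower number from compound 1 to compound 4 (0.19 log units; within the scatter) in the same read-out. Among these four compounds, the methoxy for fluoro change is thus the only single-place step that clears the scatter.

As far as these compounds go, whether a hydroxyl, an amine or a longer ether chain at this position would behave like the methoxy or like the fluoro remains open. Nothing shown here gives a reason for the step.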